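This account rests on a few compounds, and the source may have more. Where it says the series, first, only, none or still open, it means among the compounds named here.

Compound 1 `CCS(=O)(=O)N1CCC(c2cncc(N3C(=O)c4ccc(Cl)cc4C3(C)C)c2)CC1`: 3 nM
Compound 2 `CC(=O)N1CCN(c2cncc(N3C(=O)c4ccc(Cl)cc4C3(C)C)c2)CC1`: 9 nM
Compound 3 `CC(=O)NCc1cncc(N2C(=O)c3ccc(Cl)cc3C2(C)C)c1`: 59 nM

In an assay on cells for inhibition of cytochrome P450 11B2, mitochondrial (Homo sapiens), read by HTRF (a lower number here means a stronger inhibitor, a higher number a weaker inhibitor), compound 3 gives the highest number of the three measured compounds; the nearest value is that of compound 2, and the most distant is that of compound 1. For the measured compounds named here, the single measured step that ends at compound 3 is a 6.6-fold higher number from compound 2 to compound 3 (0.82 log units; beyond the scatter): swapping a ring-bearing acetyl group for a short open chain raised the number clearly beyond the scatter.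

Compound 4 `CC(=O)N1CCC(c2cncc(N3C(=O)c4ccc(Cl)cc4C3(C)C)c2)CC1` has not been measured. It differs from compound 3 by 1-acetylpiperidin-4-yl in place of acetamidomethyl on an aromatic carbon. This change goes the opposite way to the measured step: the open acetamidomethyl chain gives way to a six-membered ring carrying an acetyl group, much as in compound 2, while compound 1 shows that a related ring with a different substituent also sits at a low number. A step in this assay of similar size to the measured one, but downward, is therefore expected, about a 12-fold lower number from compound 3 to compound 4 (1.07 log units; beyond the scatter). Compound 4 is estimated at 5 nM, with a likely range from 2 nM to 15 nM.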

Compound 4, half-maximal inhibitory concentration: 5 nM
For compound 4 middle estimate and measured number coincide at the digits printed; measured number inside the range.
By their numbers in this assay, from the lowest: compounds 1, 4 and 2 (each within the scatter of the next, the first and the last beyond it); then compound 3.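

In this assay, putting 1-acetylpiperidin-4-yl on this aromatic carbon in place of acetamidomethyl gives a 12-fold lower number from compound 3 to compound 4 (1.07 log units; beyond the scatter), so a ring with just one nitrogen serves as well here as the ring of compound 2. That comparison shows no separation between the two rings: 1-acetylpiperidin-4-yl in place of 4-acetylpiperazin-1-yl gives a 1.8-fold lower number from compound 2 to compound 4 (0.26 log units; within the scatter). The group on the ring nitrogen is not separated either, since acetyl in place of ethylsulfonyl gives a 1.7-fold higher number from compound 1 to compound 4 (0.22 log units; within the scatter).

Nothing available explains the large gap between the open chain and the ring compounds. On these data alone, it remains open how a free amine on that ring nitrogen, or a longer open chain in place of acetamidomethyl, would read in this assay.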